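Two Chlorines Replace Bromine on the Pendant Phenyl

A few compounds are considered here, and "the series" means these few. Any claim that something is new, unique, unknown or untested is made for them only; others in the source may bear on it.

Compound 2 `O=C(CCCCC1CCSS1)NCc1cn(CCCCOc2ccc3cc(-c4ccc(Br)cc4)c(=O)oc3c2)nn1` gives 37.4% in a functional assay on PC-12 cells (Rattus norvegicus) for cytotoxicity, read by MTT assay, with stated times of 3 h and 2 h, tested at 1 uM; a higher number here means a stronger effect of the compound at the concentration tested, a lower number a weaker effect. Compound 1 `O=C(CCCCC1CCSS1)NCc1cn(CCCCOc2ccc3cc(-c4ccccc4)c(=O)oc3c2)nn1` gives 34.8% in this assay, and the step between them, a number 2.6 percentage points higher from compound 1 to compound 2 (within the scatter), means compound 2 stands level with compound 1 rather than apart from it. Compound 3 `O=C(CCCCC1CCSS1)NCc1cn(CCCCOc2ccc3cc(-c4ccc(Cl)c(Cl)c4)c(=O)oc3c2)nn1` differs from compound 2 by 3,4-dichlorophenyl in place of 4-bromophenyl on an aromatic carbon. Among the measured compounds shown here, the only step that bears on this exchange of one halogenated phenyl for another is the one from compound 1 to compound 2, and it was small. A change within the scatter is therefore expected, a number 0.4 percentage points lower from compound 2 to compound 3 (within the scatter). Compound 3 is estimated at 37%, with a range from 26% to 48%.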

Compound 3, a percentage reported as activity, at one concentration (the size of the read-out at that concentration, not a potency): 49.3%
Estimate against measurement, compound 3: 12.3 percentage points below; the whole stated range lies below it.
By their numbers in this assay, from the lowest: compounds 1 and 2 (each within the scatter of the next); then compound 3.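

In this assay, 3,4-dichlorophenyl at this position gives a number 11.9 percentage points higher from compound 2 to compound 3 (beyond the scatter) and also a number 14.5 percentage points higher from compound 1 to compound 3 (beyond the scatter) so the pendant phenyl can move this read-out, which the step from hydrogen to bromo did not show. Two halogenated phenyl groups are therefore not interchangeable here, even though 4-bromophenyl stands level with plain phenyl. Nothing available explains this rise.
Going by these compounds, whether it needs both chlorines or only one remains open. So does the result of carrying an amine or a methoxy group on this phenyl instead.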